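The compounds below may be only part of what the source reports. "The series", "measured", "known", "first", "only" and "open" are said of these compounds alone.

Compound 3 `Cc1ccccc1C(=O)Nc1ccc(S(=O)(=O)NC2CCN(C(=O)CN)CC2)c2ccccc12` gives 4.1 nM in an assay on L1.2 cells for binding affinity to C-C chemokine receptor type 8 (Homo sapiens) (a higher number here means a weaker inhibitor, a lower number a stronger inhibitor), the highest of the two numbers reported. Compound 1 `CCOC(=O)N1CCC(NS(=O)(=O)c2ccc(NC(=O)c3ccccc3)c3ccccc23)CC1` gives 0.17 nM, a lower number by a gap beyond the usual scatter. Compound 2 `CCOC(=O)N1CCC(NS(=O)(=O)c2ccc(O)c3ccccc23)CC1` reaches only a limit of this assay, > 5000 nM, which is the limit of > 5000 nM in this assay, at which 1 of the 3 values shown sits. Going by the values given here, the single measured step, an at least 29000-fold higher number from compound 1 to compound 2 (4.46 log units; beyond the scatter), lies at a different place on the shared core and so does not directly bear on the change to compound 4 `Cc1ccccc1C(=O)Nc1ccc(S(=O)(=O)NC2CCN(C(=O)N3CCCCC3)CC2)c2ccccc12`, which is piperidin-1-yl in place of aminomethyl on a carbonyl carbon. Among the compounds with values here, with no measured step at that place, no direction is fixed, and a modest shift is expected, a 2.1-fold lower number from compound 3 to compound 4 (0.31 log units; beyond the scatter). Compound 4 is therefore estimated at 2 nM, with a plausible range from 0.4 nM to 10 nM.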

Compound 4, inhibition constant: 4.2 nM
The estimate for compound 4 lay 2.1-fold (0.32 log units) below the measured number; low and high end bracket the measured number.
By their numbers in this assay, from the lowest: compound 1; then compounds 3 and 4 (each within the scatter of the next). At a limit, above all of these: compound 2.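

Going by these compounds alone, this is the first measured step at this place, on a carbonyl carbon whose other neighbour is an amide-type nitrogen in a ring. In this assay, piperidin-1-yl in place of aminomethyl gives a 1.0-fold higher number from compound 3 to compound 4 (0.01 log units; within the scatter), so a six-membered ring and a group with a hydrogen-bond donor cannot be told apart here. Nothing measured explains why these two groups read alike. As far as these compounds go, whether a morpholin-4-yl group or a longer chain ending in an amine would read the same stays open. So does how much of the gap to compound 1 belongs to this carbonyl substituent, since compound 1 differs from compound 3 in more than one place.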